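Lengthening the linker chain toward an eleventh carbon

A few compounds are considered here, and "the series" means these few. Any claim that something is new, unique, unknown or untested is made for them only; others in the source may bear on it.

Three compounds share one core and differ only in the length of the saturated chain that joins the sulfur to the (2,4-dichlorophenyl)carbamoyl group. In an assay on isolated protein (Mus musculus) for inhibition of IL15-IL15 receptor (Homo sapiens), read by resazurin assay, with stated times of 30 min and 2.5 days (a higher number here means a weaker inhibitor, a lower number a stronger inhibitor), compound 1 `Cn1c(Cc2nn(C)c(=O)c3ccccc23)nnc1SCCCC(=O)Nc1ccc(Cl)cc1Cl` gives 9800 nM, compound 2 `Cn1c(Cc2nn(C)c(=O)c3ccccc23)nnc1SCCCCCC(=O)Nc1ccc(Cl)cc1Cl` gives 4100 nM and compound 3 `Cn1c(Cc2nn(C)c(=O)c3ccccc23)nnc1SCCCCCCCCCC(=O)Nc1ccc(Cl)cc1Cl` gives 2300 nM. Compound 3 thus has the lowest number of the three; its gap to compound 2 lies within the usual scatter, while its gap to compound 1 lies beyond it. The numbers fall as the chain grows, and no compound among these three goes against that.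

Compound 4 `Cn1c(Cc2nn(C)c(=O)c3ccccc23)nnc1SCCCCCCCCCCC(=O)Nc1ccc(Cl)cc1Cl` extends the chain by one more carbon: ((2,4-dichlorophenyl)carbamoyl)methyl in place of (2,4-dichlorophenyl)carbamoyl on a saturated chain carbon, nine bonds along the chain from a sulfur. That is the smallest change seen in this set, far smaller than the jumps between the three measured compounds. The expected step in this assay from compound 3 to compound 4 is a 1.2-fold lower number from compound 3 to compound 4 (0.06 log units; within the scatter), that is, none beyond the scatter, with at most a slight drift downward. Compound 4 is therefore estimated at 2000 nM, with a likely range from 900 nM to 4500 nM.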

Compound 4, half-maximal inhibitory concentration: 3300 nM
The estimate for compound 4 lay 1.7-fold (0.22 log units) below the measured number; low and high end bracket the measured number.
By their numbers in this assay, from the lowest: compounds 3, 4 and 2 (each within the scatter of the next); then compound 1.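

In this assay, adding one carbon to the chain gives a 1.4-fold higher number from compound 3 to compound 4 (0.16 log units; within the scatter), so this single extra carbon has no readable effect on the number. The numbers fell as the chain grew across compound 1, compound 2 and compound 3, but that fall does not visibly continue at compound 4, and the result gives no sign of a real reversal either. At this chain length the position accepts ((2,4-dichlorophenyl)carbamoyl)methyl in place of (2,4-dichlorophenyl)carbamoyl with no difference that can be told from the usual scatter, and no measurement at hand offers a reason for this.

Still open, as far as these compounds go, is whether a longer chain would move the number beyond the scatter. Also open, from the compounds shown here alone, is what an amine or an ether oxygen within the chain would do.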